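Phenyl for phenoxy on the shared core of compound 2

This account rests on a few compounds, and the source may have more. Where it says the series, first, only, none or still open, it means among the compounds named here.

Three compounds of the series have been run in a functional assay on the whole organism (strain Sprague-Dawley CD) for inhibition, with Rattus norvegicus as the target, read by paw edema, at a dose of 100 mg/kg by the oral route; on this read-out lower numbers stand for a weaker effect and higher numbers for a stronger effect at the one dose given. Compound 1, `CCOC(=O)C(=O)Nc1c(Oc2ccccc2)ccccc1=O`, gives 20%. Compound 2, `CCOC(=O)C(=O)Nc1ccccc(Oc2ccccc2)c1=O`, gives 9%. Compound 3, `CCOC(=O)C(=O)Nc1ccccc(O)c1=O`, gives 0%. Compound 2 thus stands second of the three numbers, with compound 3 nearest and compound 1 furthest from it; the gap between compound 2 and compound 3 lies within the scatter, the gap between compound 2 and compound 1 beyond it.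

For the measured compounds named here, the one step that has been measured in this assay is a number 9 percentage points lower from compound 2 to compound 3 (within the scatter), a change of hydrogen in place of phenyl on an oxygen on an aromatic ring, and it is within the scatter. Going by the values given here, no step from phenoxy to phenyl has been measured, so nothing bears directly on the next change.

Compound 4, `CCOC(=O)C(=O)Nc1ccccc(-c2ccccc2)c1=O`, differs from compound 2 as follows: phenyl in place of phenoxy on an aromatic carbon. Given that the only measured step at this position stays within the scatter, no step beyond the scatter is expected in this assay for the move to compound 4; compound 4 is therefore estimated at 10%, in the range 0% to 28%. The expected step is a number 1 percentage points higher from compound 2 to compound 4 (within the scatter).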

Compound 4, a percentage reported as inhibition, in the whole organism at one dose (the size of the read-out at that dose, not a potency): 0%
Beside the measured number, compound 4's estimate is 10 percentage points above it; the measured number falls inside the stated range.
By their numbers in this assay, from the lowest: compounds 3, 4 and 2 (each within the scatter of the next); then compound 1.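

In this assay, for the compounds shown here, the phenoxy-to-phenyl change gives a number 9 percentage points lower from compound 2 to compound 4 (within the scatter), so the first direct reading of this change shows no step beyond the scatter when phenyl stands on the aromatic carbon in place of phenoxy. The comparison with the hydroxy compound gives no change at the digits printed from compound 3 to compound 4 (within the scatter), and together with a number 9 percentage points lower from compound 2 to compound 3 (within the scatter) it places phenoxy, hydroxy and phenyl within the scatter of one another at this position of the seven-membered aromatic ring, so the three groups are not separated at the one oral dose. Nothing on hand offers an explanation for these numbers.

Still open, from the compounds shown here alone, is whether an amine, a carboxylic acid or a longer alkyl chain on this aromatic carbon would give a step beyond the scatter from compound 2. Also open is whether phenyl would keep the level of compound 1 , which gives 20%, if it took the place of phenoxy on that compound's shared core, since the series shown holds no pair that reads this change there.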